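The source may report more compounds than this note shows. Statements on the series, on what has been measured and on what is new or still open speak of the compounds shown alone.

Measured compounds in a functional assay on U-937 cells (Homo sapiens) for cytotoxicity, read by resazurin assay, with a stated time of 72 h; a higher number here means a weaker inhibitor, a lower number a stronger inhibitor:
Compound 1 `COc1cc(OC)c(C(C)=O)c(OC)c1` gives 7200 nM.
Compound 2 `COc1cc(OC)c(C(=O)/C=C/c2ccccc2)c(OC)c1` gives 6700 nM.
Compound 3 `COc1cc(OC)c(C(=O)/C=C/c2ccccc2)c(OC)c1Cc1ccccc1O` gives 4200 nM.

Compound 1 has the highest of the three numbers, but the gaps to compound 2 and to compound 3 are small and fall within the usual scatter of this measurement, so no ordering among the three can be claimed. Among the measured compounds shown here, the only step with a single structural change is a 1.6-fold lower number from compound 2 to compound 3 (0.20 log units; within the scatter), and it too stays within the scatter; it concerns a group placed on an aromatic carbon and says nothing about the change examined here.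

Compound 4 `COCOc1cc(OC)cc(OC)c1C(C)=O` differs from compound 1 by methoxy in place of hydrogen on a saturated chain carbon bound to an oxygen on an aromatic ring. For the measured compounds named here, no measured pair shows this kind of change, so there is no step to lean on. With the shared core and the acetyl group kept and the only difference a small extension at one methoxy group, the plainest expectation is a number close to that of compound 1, with no step beyond the scatter in either direction.

Compound 4 is therefore estimated at 7000 nM, with a range from 3000 nM to 16000 nM, which corresponds to an expected 1.0-fold lower number from compound 1 to compound 4 (0.01 log units; within the scatter).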

Compound 4, half-maximal inhibitory concentration: 13300 nM
Compound 4: middle estimate off by 1.9-fold (0.28 log units), on the low side; low and high end bracket the measured number.
By their numbers in this assay, from the lowest: compounds 3, 2, 1 and 4 (each within the scatter of the next, the first and the last beyond it).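

In this assay, among the compounds shown here, the swap of methoxy for methoxymethoxy on the shared core is the first change at this position that can be read, and it gives a 1.8-fold higher number from compound 1 to compound 4 (0.27 log units; within the scatter). The earlier step concerned a group on an aromatic carbon, so this pair is the only one that speaks to the saturated chain carbon bound to an oxygen on an aromatic ring, and it shows that adding a methoxy group there leaves a difference that cannot be told apart from repeat-measurement scatter in this cell assay, though a single pair on the small acetyl compound is thin ground. No measurement shown here offers an explanation for this step, whatever its true size may be.

On these data alone, it remains open whether a larger replacement at this place, such as a longer chain, an amine or a carboxylic acid in place of the methoxymethoxy group, would give a step beyond the scatter. As far as these compounds go, it is also open whether methoxymethoxy would read the same way on the cores of compound 2 and compound 3, which both carry plain methoxy there.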